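A shorter hydroxyalkoxy chain on the oxime

The compounds below may be only part of what the source reports. "The series", "measured", "known", "first", "only" and "open" are said of these compounds alone.

Three compounds share one core and differ only in the group on the double-bonded nitrogen of the oxime. Compound 1 `CCO/N=C/c1c(N)ncnc1Oc1ccc(NC(=O)C2(C(=O)Nc3ccc(F)cc3)CC2)cc1F` carries an ethoxy there, and in a physicochemical assay for lipophilicity, using the shake flask method (a lower number here means a more polar compound, a higher number a more lipophilic compound), compound 1 gives 3.41. Compound 2 `N/N=C/c1c(N)ncnc1Oc1ccc(NC(=O)C2(C(=O)Nc3ccc(F)cc3)CC2)cc1F` carries an amino group instead, and in this assay compound 2 gives 2.25; the change reads a number 1.16 log units lower from compound 1 to compound 2 (beyond the scatter). Compound 3 `Nc1ncnc(Oc2ccc(NC(=O)C3(C(=O)Nc4ccc(F)cc4)CC3)cc2F)c1/C=N/OCCCO` carries a 3-hydroxypropoxy group, and in this assay compound 3 gives 2.67, which places it second highest of the three, with a number 0.74 log units lower from compound 1 to compound 3 (beyond the scatter) and a number 0.42 log units higher from compound 2 to compound 3 (beyond the scatter).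

Compound 4 `Nc1ncnc(Oc2ccc(NC(=O)C3(C(=O)Nc4ccc(F)cc4)CC3)cc2F)c1/C=N/OCCO` is the next member: hydroxy in place of hydroxymethyl on a saturated chain carbon, two bonds along the chain from an oxygen. Going by the values given here, two measured steps bear on this. The step from compound 1 to compound 3 added the hydroxymethyl and lowered the value beyond the scatter; the step from compound 2 to compound 3 shows that the full 3-hydroxypropoxy chain sits well above the amino analogue. Cutting one carbon from that chain, while keeping the hydroxy, is expected to move the value down by a modest amount, smaller than either measured step. For compound 4 the expected step is a number 0.37 log units lower from compound 3 to compound 4 (beyond the scatter), giving an estimate of 2.3, within a range from 1.9 to 2.7.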

Compound 4, partition coefficient: 2.37
Compound 4: middle estimate off by 0.07 log units, on the low side, and the stated range covers the measured number.
By their numbers in this assay, from the lowest: compounds 2, 4 and 3 (each within the scatter of the next, the first and the last beyond it); then compound 1.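

Putting 2-hydroxyethoxy in the place of 3-hydroxypropoxy reads a number 0.30 log units lower from compound 3 to compound 4 (within the scatter) in this assay, so at this position the removal of one chain carbon with the hydroxy kept gives a step that cannot be told from the usual scatter. The same holds against the amino analogue, where 2-hydroxyethoxy in place of amino on a double-bonded nitrogen reads a number 0.12 log units higher from compound 2 to compound 4 (within the scatter), so compound 4 lies within the scatter of both compound 2 and compound 3, even though those two are separated by a number 0.42 log units higher from compound 2 to compound 3 (beyond the scatter). Only the comparison with the ethoxy group remains clear, since hydroxy in place of hydrogen on a saturated chain carbon, two bonds along the chain from an oxygen, reads a number 1.04 log units lower from compound 1 to compound 4 (beyond the scatter), a large step for the one place in which these two compounds differ.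

No measurement shown gives a reason for the size of any of these steps. The compounds shown leave open how 4-hydroxybutoxy, 2-methoxyethoxy or 2-aminoethoxy on the double-bonded nitrogen would read in this assay.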